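Removing the methyl from compound 2

The compounds below may be only part of what the source reports. "The series", "measured", "known", "first", "only" and "open" are said of these compounds alone.

Compound 1 (`O=C(NCc1ccc(S(=O)(=O)c2ccccc2C(F)(F)F)cc1)c1cc2cnccc2[nH]1`) with 52% remaining
Compound 2 (`Cn1c(C(=O)NCc2ccc(S(=O)(=O)c3ccccc3)cc2)cc2cnccc21`) with 78% remaining

In an ADME assay on microsomes from liver (Homo sapiens) for metabolic stability, read by LC-MS, with a stated time of 30 min, tested at 1 uM (a lower number here means that less of the compound is left, a higher number that more of the compound is left), compound 2 stands highest of the two, and compound 1 lies lower by a gap beyond the usual scatter. Compound 3 (`O=C(NCc1ccc(S(=O)(=O)c2ccccc2)cc1)c1cc2cnccc2[nH]1`) is compound 2 with hydrogen in place of methyl on an aromatic nitrogen. Going by the values given here, no measured pair shows this change alone, so the data give no direct size for it. Compound 1 also has hydrogen on that nitrogen and gives 52% there, but it carries a trifluoromethyl group as well, which makes that value only a loose guide. The step expected in this assay is a modest fall (a number 10 percentage points lower from compound 2 to compound 3 (within the scatter)), not clearly beyond the scatter. The estimated value for compound 3 is 68% (48% to 85%).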

Compound 3, percent of the compound remaining: 75%
The estimate for compound 3 lay 7 percentage points below the measured number, within the range that was stated.
By their numbers in this assay, from the lowest: compound 1; then compounds 3 and 2 (each within the scatter of the next).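

In this assay, hydrogen in place of methyl on an aromatic nitrogen gives a number 3 percentage points lower from compound 2 to compound 3 (within the scatter) and so leaves no readable difference between these two groups at this position. The other change, hydrogen in place of trifluoromethyl on an aromatic carbon, gives a number 23 percentage points higher from compound 1 to compound 3 (beyond the scatter) with hydrogen on the nitrogen in both compounds, so the lower number of compound 1 goes with the trifluoromethyl group and not with the free nitrogen. Nothing here gives a measured reason for either step.

On these data alone, how an ethyl group, or a longer chain ending in an amine, would behave on that nitrogen stays open. Also open, as far as these compounds go, is whether a chlorine atom or a methoxy group on that aromatic carbon would follow trifluoromethyl or hydrogen.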